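Swapping the amide aryl group in a weakly active series

The source may hold more compounds than are shown below. What is called first, only, known or untested is meant among the compounds shown, and "the series" means these compounds.

Compound 1 `NC(=O)c1c(NC(=O)c2ccc(C(F)(F)F)cc2)sc2c1CCN(Cc1ccc(Cl)cc1)C2` and compound 2 `NC(=O)c1c(NC(=O)c2ccc(C(F)(F)F)cc2)sc2c1CCN(Cc1c(Cl)cccc1Cl)C2` share one core and were both tested in a functional assay on MKN-74 cells (Homo sapiens) for antiproliferative activity, with a stated time of 24 h; on this read-out higher numbers stand for weaker inhibition and lower numbers for stronger inhibition. For compound 1 the result is only a limit of the assay, > 50000 nM. Within the data shown here, compound 2 gives 8530 nM, the single numerical value in the set. The step of an at least 5.8-fold lower number from compound 1 to compound 2 (0.76 log units; beyond the scatter) comes with 2,6-dichlorophenyl in place of 4-chlorophenyl on a saturated chain carbon bound to an amine nitrogen in a ring. Compound 3 `NC(=O)c1c(NC(=O)c2cccc([N+](=O)[O-])c2)sc2c1CCN(Cc1c(Cl)cccc1Cl)C2` differs from compound 2 by 3-nitrophenyl in place of 4-(trifluoromethyl)phenyl on a carbonyl carbon. Among the measured compounds shown here, no measured step touches the group on the carbonyl carbon, so the set offers no guide there; a change within the scatter is expected, a 1.2-fold higher number from compound 2 to compound 3 (0.07 log units; within the scatter). Compound 3 is therefore estimated at 10000 nM, between 2500 nM and 40000 nM.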

Compound 3, half-maximal inhibitory concentration: 13500 nM
Compound 3: the middle estimate sits 1.4-fold (0.13 log units) below what was measured; measured number inside the range.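

In this assay, among these compounds, the group on the carbonyl carbon can now be read for the first time: 3-nitrophenyl in place of 4-(trifluoromethyl)phenyl gives a 1.6-fold higher number from compound 2 to compound 3 (0.20 log units; within the scatter). These two aryl groups therefore cannot be told apart at this position, with the 2,6-dichlorophenyl group held constant. Only compound 1 stands at a limit of the assay: the limit of > 50000 nM in this assay, at which 1 of the 3 values shown sits.

The compounds shown leave open whether an amine or a carboxylic acid on the phenyl ring at the carbonyl carbon would give a step beyond the scatter. Going by these compounds, whether 3-nitrophenyl would read the same alongside 4-chlorophenyl also stays open.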